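This account rests on a few compounds, and the source may have more. Where it says the series, first, only, none or still open, it means among the compounds named here.

Compound 1 `CCCCN1CCc2nc(C#Cc3ccccc3)sc2C1` stands at the edge of what this study can resolve. In an assay on HEK293 cells for negative allosteric modulation of metabotropic glutamate receptor 5 (Homo sapiens), read by FLIPR, with a stated time of 1 h (on this read-out lower numbers stand for stronger inhibition and higher numbers for weaker inhibition), compound 1 gives no number but only the assay limit of > 10000 nM; this is the limit of > 10000 nM in this assay, at which 1 of the 2 values shown sits. Going by the values given here, compound 2 `Fc1cccc(C#Cc2nc3c(s2)CN(C2CCOC2)CC3)c1` carries the one real number, and in this assay compound 2 gives 400 nM. Compound 3 `CC1CC(C(=O)N2CCc3nc(C#Cc4ccccc4)sc3C2)C1` differs from compound 1 by (3-methylcyclobutyl)carbonyl in place of butyl on an amine nitrogen in a ring. Among the compounds with values here, no measured pair shares this change, so the step of an at least 5.0-fold lower number from compound 1 to compound 3 (0.69 log units; beyond the scatter) is expected to be a gain reaching beyond the scatter, held with little certainty. Compound 3 is therefore estimated at 2000 nM, within a range from 300 nM to 10000 nM.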

Compound 3, half-maximal inhibitory concentration: > 10000 nM
Compound 3: no number, only a limit; the forecaster's own chance of this, stated with the estimate: 35%; middle value at least 5.0-fold (0.69 log units) away from the limit.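

Going by these compounds alone, compound 1 and compound 3 both stop at a limit in this assay, so no step between them can be read: the limit of > 10000 nM in this assay, at which 2 of the 3 values shown sit. Going by these compounds, whether (3-methylcyclobutyl)carbonyl in place of butyl changes inhibition at all stays open.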